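This account rests on a few compounds, and the source may have more. Where it says the series, first, only, none or still open, it means among the compounds named here.

Compound 1 `CCOC(=O)c1cnc(N2CCN(C(=O)NS(=O)(=O)c3ccc(Cl)s3)CC2)c(Cl)c1`: > 70000 mL.min-1.g-1
Compound 2 `CC(C)OC(=O)c1cnc(N2CCN(C(=O)NS(=O)(=O)c3ccc(Cl)s3)CC2)c(Cl)c1`: > 70000 mL.min-1.g-1

In an ADME assay on microsomes from liver (Homo sapiens) for metabolic stability, read by LC-MS, using NADPH (a lower number here means slower removal, a higher number faster removal of the compound), compound 2 gives > 70000 mL.min-1.g-1, which is a limit of the assay and not a number. Compound 1 gives > 70000 mL.min-1.g-1, which is also a limit. Compound 3 `CC(C)CCOC(=O)c1cnc(N2CCN(C(=O)NS(=O)(=O)c3ccc(Cl)s3)CC2)c(Cl)c1` keeps the shared core and differs from compound 2 in one place: isopentyl in place of isopropyl on an oxygen next to a carbonyl group. In words, isopentyl stands in place of isopropyl on an oxygen next to a carbonyl group. Going by the values given here, one measured step bears on this change, a step that the two limits leave unreadable from compound 1 to compound 2, and it has no readable size. The evidence is the limit of > 70000 mL.min-1.g-1 in this assay, at which 2 of the 2 values shown sit. The data therefore give no size for a change at this place, and compound 3 is expected to stay at the same limit. The expected step is a step that the limit leaves unreadable from compound 2 to compound 3. The estimate for compound 3 is 80000 mL.min-1.g-1, with an expected range of 35000 mL.min-1.g-1 to 200000 mL.min-1.g-1.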

Compound 3, intrinsic clearance in microsomes in the Homo sapiens assay: > 70000 mL.min-1.g-1
Compound 3 ended at the assay's limit; the forecaster's own chance of this, stated with the estimate: 85%; the middle value is on the limit's open side.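

In the Homo sapiens assay compound 1 gives > 70000 mL.min-1.g-1, which is a limit of the assay and not a number. In the Homo sapiens assay compound 2 gives > 70000 mL.min-1.g-1, which is a limit of the assay and not a number. In the Homo sapiens assay compound 3 gives > 70000 mL.min-1.g-1, which is a limit of the assay and not a number. No step can be read between compound 1, compound 2 and compound 3 in the Homo sapiens assay, because each result is a limit of the assay and not a number: the limit of > 70000 mL.min-1.g-1 in the Homo sapiens assay, at which 3 of the 3 values shown sit.

The compounds shown leave open how fast each is actually removed, and whether isopentyl and isopropyl differ at all on this read-out.

In a physicochemical assay (on this read-out lower numbers stand for a less stable compound and higher numbers for a more stable compound), compound 2 gives "stable" (no number reported). In the physicochemical assay compound 3 gives "stable" (no number reported).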